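Nitro in Place of Hydrogen: Expected Tolerance of Compound 4

The source may hold more compounds than are shown below. What is called first, only, known or untested is meant among the compounds shown, and "the series" means these compounds.

Three compounds with a shared core were tested in an ADME assay on HeLa cells (Homo sapiens) for cytotoxicity, read by microscopy; a lower number here means that less compound is tolerated, a higher number that more compound is tolerated. Compound 1 `CSc1nc(NCCCNc2ccnc3cc(Cl)ccc23)c(C#N)c(-c2ccccc2)n1` gives 100000 nM in this assay. Compound 3 `CSc1nc(NCCCCNc2ccnc3cc(Cl)ccc23)c(C#N)c(-c2ccc([N+](=O)[O-])cc2)n1`, which carries a nitro group and a different linker, gives 4000 nM. Compound 2 `CSc1nc(-c2ccccc2)c(C#N)c(N2CCN(c3ccnc4cc(Cl)ccc34)CC2)n1` reached only a limit of > 100000 nM in this assay, (the limit of > 100000 nM in this assay, at which 1 of the 3 values shown sits). For the measured compounds named here, compound 1 and compound 3 differ in more than one place, so no single step is drawn between them; their two values nonetheless lie far apart, with the nitro-bearing compound 3 tolerated less. Compound 4 `CSc1nc(-c2ccc([N+](=O)[O-])cc2)c(C#N)c(N2CCN(c3ccnc4cc(Cl)ccc34)CC2)n1` has not yet been measured and differs from compound 2 by nitro in place of hydrogen on an aromatic carbon. A step downward beyond the scatter is expected for compound 4, an at least 10-fold lower number from compound 2 to compound 4 (1.00 log units; beyond the scatter). Compound 4 is estimated at 10000 nM, between 2000 nM and 100000 nM.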

Compound 4, minimum cytotoxic concentration: > 100000 nM
Compound 4: a limit, no number; the forecaster's own chance of this, stated with the estimate: 25%; middle value at least 10-fold (1.00 log units) from the limit.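

Compound 2 and compound 4 both end at a limit, not a number, so no step between them can be read in this assay: the limit of > 100000 nM in this assay, at which 2 of the 4 values shown sit.

From the compounds shown here alone, whether nitro in place of hydrogen changes tolerance in this pair, and by how much, stays open.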